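The source may hold more compounds than are shown below. What is called first, only, known or untested is meant among the compounds shown, and "the series" means these compounds.

Measured so far in an assay for inhibition of Dihydrofolate reductase (Bos taurus), at pH 7.20; a lower number here means a less potent compound, a higher number a more potent compound, by a factor of ten per unit of this negative logarithm:
- compound 1, `CC1(C)N=C(N)N=C(N)N1c1ccccc1S`: 7.69
- compound 2, `CC1(C)N=C(N)N=C(N)N1c1ccccc1F`: 5.41
- compound 3, `CC1(C)N=C(N)N=C(N)N1c1ccccc1Cl`: 5.19

Compound 1 stands highest of the three, and it stands alone: compound 2 lies a number 2.28 log units lower from compound 1 to compound 2 (beyond the scatter) and compound 3 lies a number 2.50 log units lower from compound 1 to compound 3 (beyond the scatter), both beyond the scatter. Between compounds 2 and 3 the gap is a number 0.22 log units lower from compound 2 to compound 3 (within the scatter), within the scatter, so the two halogen analogues are read as level with each other.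

Compound 4, `CC1(C)N=C(N)N=C(N)N1c1ccccc1C(F)(F)F`, is not yet measured. Its difference from compound 1 is trifluoromethyl in place of sulfanyl on an aromatic carbon. The two measured steps that bear on this are exactly those from compound 1: each time the sulfanyl group on that aromatic carbon was replaced, by fluoro or by chloro, the number in this assay fell by more than two units, and the two replacements landed within the scatter of each other. The trifluoromethyl group, like fluoro and chloro, brings no hydrogen-bond donor and no acceptor where sulfanyl had one of each. A large step downward in this assay is therefore expected for compound 4, of about a number 2.29 log units lower from compound 1 to compound 4 (beyond the scatter). The estimate for compound 4 is 5.4, with a range from 4.7 to 6.3.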

Compound 4, logarithm of the reciprocal of the active concentration, log(1/C): 3.53
Beside the measured number, compound 4's estimate is 1.87 log units above it; the whole stated range lies above it.
By their numbers in this assay, from the lowest: compound 4; then compounds 3 and 2 (each within the scatter of the next); then compound 1.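

In this assay, the change to trifluoromethyl on this aromatic carbon gives a far larger loss than either halogen did, with a number 4.16 log units lower from compound 1 to compound 4 (beyond the scatter) as the step from the sulfanyl compound. The earlier compounds shown here could be read as showing a single lower level reached once sulfanyl left, since fluoro and chloro lay within the scatter of each other, but trifluoromethyl falls well below that level, with a number 1.66 log units lower from compound 3 to compound 4 (beyond the scatter) and a number 1.88 log units lower from compound 2 to compound 4 (beyond the scatter) as its steps from the two halogen analogues. Removing sulfanyl therefore does not by itself fix the outcome at this position, and the group that enters also matters, although nothing shown here gives a measured reason for the further fall.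

The compounds shown leave open whether the high number belongs to sulfanyl alone or would also appear with a hydroxyl group, an amine or a methylsulfanyl group on the same carbon. They also leave open whether a methyl group or a longer alkyl chain there would stay near the halogen analogues or fall as far as the trifluoromethyl compound.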